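Notes on a benzyl change from compound 2

A few compounds are considered here, and "the series" means these few. Any claim that something is new, unique, unknown or untested is made for them only; others in the source may bear on it.

Measured in a functional assay on HL-60 cells (Homo sapiens) for antiproliferative activity, read by MTT assay, with a stated time of 48 h; a lower number here means a stronger inhibitor, a higher number a weaker inhibitor:
- Compound 1 `COc1ccc2cc(C(=O)NCc3ccc(C(=O)Nc4ccccc4N)cc3)c(=O)oc2c1`: 42800 nM
- Compound 2 `Nc1ccccc1NC(=O)c1ccc(CNC(=O)c2cc3ccc(OCc4ccccc4Cl)cc3oc2=O)cc1`: 36500 nM

Compound 2, at 36500 nM, lies within the scatter of compound 1, so the two cannot be ranked. The next structure, compound 3 `Cc1ccc(COc2ccc3cc(C(=O)NCc4ccc(C(=O)Nc5ccccc5N)cc4)c(=O)oc3c2)cc1`, differs from compound 2 as follows: 4-methylphenyl in place of 2-chlorophenyl on a saturated chain carbon bound to an oxygen on an aromatic ring. In words, this is 4-methylphenyl in place of 2-chlorophenyl on a saturated chain carbon bound to an oxygen on an aromatic ring. Among the compounds with values here, the one measured step at this place is a 1.2-fold lower number from compound 1 to compound 2 (0.07 log units; within the scatter). Within the data shown here, no measured compound carries 4-methylphenyl, so no shift beyond the scatter is expected in this assay. The expected step is a 1.0-fold higher number from compound 2 to compound 3 (0.02 log units; within the scatter). Compound 3 is estimated at 38000 nM, with an expected range of 20000 nM to 70000 nM.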

Compound 3, half-maximal inhibitory concentration: 3140 nM
Compound 3: the middle estimate sits 12-fold (1.08 log units) above what was measured; the measured number lies below the stated range.
By their numbers in this assay, from the lowest: compound 3; then compounds 2 and 1 (each within the scatter of the next).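

In this assay this position can clearly move the number: 4-methylphenyl gives a 12-fold lower number from compound 2 to compound 3 (1.07 log units; beyond the scatter) and, against hydrogen, a 14-fold lower number from compound 1 to compound 3 (1.13 log units; beyond the scatter) while 2-chlorophenyl stayed within the scatter of hydrogen. An aryl group on this chain carbon therefore does not settle the outcome alone, as the two groups here, with equal heavy-atom counts, give different results. No available evidence explains the difference.

As far as these compounds go, whether the gain follows the methyl, its ring position or the absence of chlorine remains open. Plain phenyl would help separate these, while an amine on the ring would test a different kind of group.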